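The source may hold more compounds than are shown below. What is called first, only, known or untested is meant among the compounds shown, and "the series" means these compounds.

Working notes on the series, read in a functional assay on DU-145 cells (Homo sapiens) for cytotoxicity, read by MTT assay; on this read-out higher numbers stand for weaker inhibition and lower numbers for stronger inhibition. Compound 1 (`CC(C)=CC[C@@H](OC[C@H](C)O)C1=CC(=O)c2c(O)ccc(O)c2C1=O`) gives 24500 nM, compound 2 (`CCCCC(O)CC(=O)O[C@H](CC=C(C)C)C1=CC(=O)c2c(O)ccc(O)c2C1=O`) gives 45300 nM and compound 3 (`CC(C)=CC[C@@H](OC(=O)CC(C)(O)C(C)C)C1=CC(=O)c2c(O)ccc(O)c2C1=O`) gives 16900 nM. Compound 3 shares the low end of these numbers with compound 1, as shown by a 1.4-fold lower number from compound 1 to compound 3 (0.16 log units; within the scatter). It separates only from compound 2, with a 2.7-fold lower number from compound 2 to compound 3 (0.43 log units; beyond the scatter).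

Compound 4 (`CCC(C)(O)CC(=O)O[C@H](CC=C(C)C)C1=CC(=O)c2c(O)ccc(O)c2C1=O`) differs from compound 3 by hydrogen in place of methyl on a saturated chain carbon bound to two saturated chain carbons, which turns isopropyl into ethyl. Among the measured compounds shown here, no measured step isolates this change. The nearest evidence is the exchange of 1-hydroxypentyl for 1-hydroxy-1,2-dimethylpropyl, a 2.7-fold lower number from compound 2 to compound 3 (0.43 log units; beyond the scatter), which is modest although it alters more of the chain than the present change does. The other side-chain exchange, a 1.8-fold higher number from compound 1 to compound 2 (0.27 log units; within the scatter), also stays small. The removal of a single methyl is therefore expected to produce no shift beyond the scatter, with a slight lean towards the higher numbers seen for compound 2. The expected step is a 1.3-fold higher number from compound 3 to compound 4 (0.11 log units; within the scatter). Compound 4 is estimated at 22000 nM, with an expected range of 11000 nM to 42000 nM.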

Compound 4, half-maximal inhibitory concentration: 16000 nM
Compound 4: the middle estimate sits 1.4-fold (0.14 log units) above what was measured; the range from low to high includes it.
By their numbers in this assay, from the lowest: compounds 4, 3, 1 and 2 (each within the scatter of the next, the first and the last beyond it).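

Among the compounds shown here, the first step to isolate this position, hydrogen in place of methyl on a saturated chain carbon bound to two saturated chain carbons, turns isopropyl into ethyl and gives (a 1.1-fold lower number from compound 3 to compound 4 (0.02 log units; within the scatter)) in this assay, so the value does not depend on this methyl. The gap to the hydroxypentyl ester also survives the trim: 1-hydroxy-1-methylpropyl in place of 1-hydroxypentyl gives (a 2.8-fold lower number from compound 2 to compound 4 (0.45 log units; beyond the scatter)), while (2-hydroxy-2-methylbutyl)carbonyl in place of 2-hydroxypropyl gives (a 1.5-fold lower number from compound 1 to compound 4 (0.19 log units; within the scatter)) and leaves compound 4 unseparated from compound 1. No data are available here that would explain why the trim leaves the value unchanged.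

The compounds shown do not tell whether the gap to compound 2 follows the length of the chain or the methyl on the hydroxyl-bearing carbon, a question that 1-hydroxypropyl, with the shorter chain but no such methyl, would address. On these data alone, it also remains open whether the hydroxyl itself matters on this side chain, as an amine in its place, or a plain butyl chain without it, would show.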